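Methyl on the pendant phenyl of compound 2

The source may hold more compounds than are shown below. What is called first, only, known or untested is meant among the compounds shown, and "the series" means these compounds.

Compound 2 `COc1cc2c(Oc3ccc(NC(=O)c4cc(-c5ccccc5)nc5ccccc45)cc3F)ccnc2cc1OCCCN1CCC(C)CC1` gives 120 nM in a functional assay on HT-29 cells (Homo sapiens) for cytotoxicity, read by MTT assay, with a stated time of 72 h (on this read-out higher numbers stand for weaker inhibition and lower numbers for stronger inhibition), the lower of the two numbers in hand, while compound 1 `COc1cc2c(Oc3ccc(NC(=O)c4cc(-c5ccccc5)nc5ccccc45)cc3F)ccnc2cc1OCCCN1CCCCC1` gives 530 nM. Compound 3 `COc1cc2c(Oc3ccc(NC(=O)c4cc(-c5ccc(C)cc5)nc5ccccc45)cc3F)ccnc2cc1OCCCN1CCC(C)CC1` differs from compound 2 by methyl in place of hydrogen on an aromatic carbon, on an aromatic carbon of a six-membered aromatic ring of carbon only, para to a large group. Among the compounds with values here, the only measured step, a 4.4-fold lower number from compound 1 to compound 2 (0.65 log units; beyond the scatter), concerns a methyl on a saturated ring carbon elsewhere in the molecule and bears on this change only loosely. Within the data shown here, no step at this aromatic position is known, so a shift within the scatter is expected, a 1.1-fold lower number from compound 2 to compound 3 (0.04 log units; within the scatter). Compound 3 is estimated at 110 nM, with a range of 40 nM to 320 nM.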

Compound 3, half-maximal inhibitory concentration: 3150 nM
The estimate for compound 3 lay 29-fold (1.46 log units) below the measured number; measured number above the stated range.
By their numbers in this assay, from the lowest: compound 2; then compound 1; then compound 3.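

In this assay the change from phenyl to 4-methylphenyl gives a 26-fold higher number from compound 2 to compound 3 (1.42 log units; beyond the scatter) and so a methyl on this aromatic carbon is poorly tolerated. The same swap of hydrogen for methyl on a saturated ring carbon gave a 4.4-fold lower number from compound 1 to compound 2 (0.65 log units; beyond the scatter) in the opposite direction, so in these compounds the outcome depends on where the methyl sits. No measurement at hand accounts for the loss.

On these data alone, whether the loss is specific to methyl remains open: fluorine, methoxy or hydroxyl on the same carbon would test this. Also open, as far as these compounds go, is whether the step holds with the unmethylated saturated ring of compound 1.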